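Moving the Thiophene Attachment Point in an Inactive Pair

The compounds below may be only part of what the source reports. "The series", "measured", "known", "first", "only" and "open" are said of these compounds alone.

Measured so far:
compound 1 `O=C(Nc1cccc(-c2ccsc2)c1)C(Cl)Cl`: > 50000 nM
compound 2 `O=C(Nc1cccc(-c2cccc(NC(=O)C(Cl)Cl)c2)c1)C(Cl)Cl`: > 50000 nM

In a functional assay on NCI-H460 cells (Homo sapiens) for cytotoxicity, read by MTT assay, with a stated time of 68 h (on this read-out lower numbers stand for stronger inhibition and higher numbers for weaker inhibition), compound 1 gives > 50000 nM, which is a limit of the assay and not a number. Compound 2 also returns only a limit, > 50000 nM. Going by the values given here, every value so far is a limit (the limit of > 50000 nM in this assay, at which 2 of the 2 values shown sit), so compound 1 stands at the limit with no measured number anywhere beside it to rank it against.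

Compound 3 `O=C(Nc1cccc(-c2cccs2)c1)C(Cl)Cl` carries the change (thiophen-2-yl in place of thiophen-3-yl on an aromatic carbon). Among the compounds with values here, with no measured step to lean on, the expected step of a number no higher from compound 1 to compound 3 (the limit leaves the size open) is none beyond the scatter, and another limit is the likeliest outcome. For compound 3 the estimate in this assay is 50000 nM, in the range 20000 nM to 120000 nM.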

Compound 3, half-maximal inhibitory concentration: > 50000 nM
Compound 3 gave a limit, no number; the forecaster's own chance of this, stated with the estimate: 75%; the middle value sits exactly at the limit.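

Going by these compounds alone, compound 1 and compound 3 both return only limits in this assay, so no step between them can be read. The compounds shown leave open whether any change to the shared core would yield a measured number.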